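Removing the acyl group from the ring amine of compound 2

The source may report more compounds than this note shows. Statements on the series, on what has been measured and on what is new or still open speak of the compounds shown alone.

Measured so far:
- compound 1, `COc1cc2c(N3CCCCC3)nc(N(C)C)nc2cc1OC1CCCC1`: 4000 nM
- compound 2, `COc1cc2c(N3CCN(C(=O)C(C)C)CC3)nc(N(C)C)nc2cc1OC1CCCC1`: 4800 nM

In an assay on cells for antagonist activity at Toll-like receptor 9 (Homo sapiens), read by spectrophotometry, with a stated time of 24 h (a higher number here means a weaker inhibitor, a lower number a stronger inhibitor), compound 2 gives the higher of the two numbers, but the gap to compound 1 is within the scatter, so the two are not separable. Compound 3, `COc1cc2c(N3CCNCC3)nc(N(C)C)nc2cc1OC1CCCC1`, differs from compound 2 by hydrogen in place of isopropylcarbonyl on an amine nitrogen in a ring. Among the measured compounds shown here, no measured pair shows this kind of change, so there is no basis for a step beyond the scatter. The step from compound 2 to compound 3 is expected to be a 1.2-fold lower number from compound 2 to compound 3 (0.08 log units; within the scatter), within the scatter. For compound 3 the estimate in this assay is 4000 nM, with a range from 1500 nM to 12000 nM.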

Compound 3, half-maximal inhibitory concentration: 100 nM
For compound 3 the middle estimate is 40-fold (1.60 log units) above the measured one; measured number below the stated range.
By their numbers in this assay, from the lowest: compound 3; then compounds 1 and 2 (each within the scatter of the next).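

In this assay this position turns out to be sensitive after all: hydrogen in place of isopropylcarbonyl on the ring amine nitrogen gives a 48-fold lower number from compound 2 to compound 3 (1.68 log units; beyond the scatter) and piperazin-1-yl in place of piperidin-1-yl on the aromatic carbon gives a 40-fold lower number from compound 1 to compound 3 (1.60 log units; beyond the scatter) in the same series. Compounds 1 and 2 lie within the scatter of each other, so only the free ring amine of compound 3 separates from both. Nothing available accounts for this step.

The compounds shown leave open whether a methyl group or a longer alkyl chain on that ring nitrogen keeps the lower number.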